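Shared core, three aryl substituents; methyl-to-ethyl step untested

This account rests on a few compounds, and the source may have more. Where it says the series, first, only, none or still open, it means among the compounds named here.

Measured compounds and their values in an assay on membranes from brain for binding affinity to adenosine receptor A1 (Rattus norvegicus), read by radioligand binding, tested at 20 uM; a lower number here means less inhibition, a higher number more inhibition at the concentration tested (going by the name of the read-out):
compound 1 `Cn1c(=O)[nH]c2c(cnn2-c2cccc([N+](=O)[O-])c2)c1=N`: 2%
compound 2 `Cn1c(=O)[nH]c2c(cnn2-c2cccc(Cl)c2)c1=N`: 53%
compound 3 `Cn1c(=O)[nH]c2c(cnn2-c2cccc(Br)c2)c1=N`: 40%

Among these three, compound 2 gives the highest number in this assay. The nearest is compound 3, and the step is a number 13 percentage points lower from compound 2 to compound 3 (beyond the scatter). Compound 1 is the furthest away, the step being a number 51 percentage points higher from compound 1 to compound 2 (beyond the scatter); the corresponding step to the bromo analogue is a number 38 percentage points higher from compound 1 to compound 3 (beyond the scatter).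

Compound 4 `CCn1c(=O)[nH]c2c(cnn2-c2cccc(Cl)c2)c1=N` is not yet measured in this assay. It differs from compound 2 by methyl in place of hydrogen on a saturated chain carbon bound to an aromatic nitrogen, which, cut one bond further out, reads methyl to ethyl. None of the three measured steps bears on this change: all of them vary the group on the aromatic carbon, and the chain on the aromatic nitrogen is the same in compound 1, compound 2 and compound 3. Within the data shown here, there is therefore no measured precedent for the size or direction of the step in this assay, and the working expectation is a step no larger than the scatter, a number 5 percentage points lower from compound 2 to compound 4 (within the scatter), with a wide range to reflect the lack of precedent. Compound 4 is estimated at 48%, between 22% and 74%.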

Compound 4, a percentage reported as inhibition, at one concentration (the size of the read-out at that concentration, not a potency): 70%
Estimate against measurement, compound 4: 22 percentage points below, within the range that was stated.
By their numbers in this assay, from the lowest: compound 1; then compound 3; then compound 2; then compound 4.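

The chain on the aromatic nitrogen, constant across compound 1, compound 2 and compound 3, is not a silent position in this assay: methyl to ethyl gives a number 17 percentage points higher from compound 2 to compound 4 (beyond the scatter), so one added carbon on this chain moves the read-out beyond the scatter. The step is modest and points toward more inhibition, which shows that this position can be varied with a gain in this assay while the chloro group stays in place. Nothing measured here accounts for the gain.

From the compounds shown here alone, whether the rise continues with a longer chain such as propyl or butyl, or stops with a branched chain such as isopropyl, remains open. Also open, going by these compounds, is whether ethyl in place of methyl gives a similar step with bromo or nitro on the aromatic carbon.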